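Compound 3: One Double Bond Redrawn from Z to E

The source may hold more compounds than are shown below. What is called first, only, known or untested is meant among the compounds shown, and "the series" means these compounds.

In a functional assay on PC-3 cells (Homo sapiens) for antiproliferative activity, read by WST assay, with a stated time of 72 h (on this read-out higher numbers stand for an effect only at larger amounts of compound and lower numbers for an effect already at smaller amounts), compound 1 (`CCCCCCCC/C=C\c1c(C)nc(C)c(/C=C\CCCCCCCC)c1C`) gives > 30 uM, which is a limit of the assay and not a number. Within the data shown here, compound 2 (`CCCCCCCC/C=C\c1c(C)c(/C=C\CCCCCCCC)c2[n+](c1C)CCC2`) gives 1.1 uM in this assay, the only actual number so far. Compound 3 (`CCCCCCCC/C=C\c1c(C)c(/C=C/CCCCCCCC)c(C)[n+]2c1CCC2`) departs from compound 2 in configuration alone: the two compounds have the same atoms and bonds and differ only in configuration as drawn: 1 of 2 stereo elements differ; a double bond is drawn Z in compound 2 and E in compound 3. Among the measured compounds shown here, no measured pair shows what such a change does, so no shift in either direction is predicted. The estimated step of a 1.3-fold higher number from compound 2 to compound 3 (0.10 log units; within the scatter) stays within the usual scatter of this assay. Compound 3 is expected at 1.4 uM, with an estimated range of 0.5 uM to 5 uM.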

Compound 3, concentration for half-maximal effect: 0.7 uM
Compound 3: middle estimate off by 2.0-fold (0.30 log units), on the high side, and the stated range covers the measured number.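

Among these compounds, this is the first measured pair in which a double bond changes from Z to E and nothing else changes, and in this assay it gives a 1.6-fold lower number from compound 2 to compound 3 (0.20 log units; within the scatter). On this read-out, compounds 2 and 3 therefore cannot be told apart, so this one redrawn double bond shows no effect beyond the scatter. The comparison is a clean one: the fact that compounds 2 and 3 differ only in the configuration as drawn

The compounds shown leave open what redrawing the second double bond from Z to E would do. They also leave open how a longer chain, or a carboxylic acid in place of one chain, would read here.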